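Four- and five-membered ring side groups: a step to estimate

The source may hold more compounds than are shown below. What is called first, only, known or untested is meant among the compounds shown, and "the series" means these compounds.

Measured in a functional assay on the whole organism for antagonist activity, with Rattus norvegicus as the target; on this read-out lower numbers stand for an effect already at smaller amounts and higher numbers for an effect only at larger amounts of compound:
- compound 1 `c1ccc2c(c1)CC2CCCN1CCN(c2cccc3c2OCCO3)CC1`: 0.18 mg/kg
- compound 2 `c1ccc2c(c1)CC2CCCCN1CCN(c2cccc3c2OCCO3)CC1`: 1.43 mg/kg

Within the data shown here, of the two numbers so far, the higher belongs to compound 2 at 1.43 mg/kg. Compound 3 `c1ccc2c(c1)CCC2CCCN1CCN(c2cccc3c2OCCO3)CC1`, not yet measured, has the same atoms as compound 2, joined differently: a group of 9 heavy atoms (9 carbon; one five-membered non-aromatic ring of carbon only, one six-membered aromatic ring of carbon only) in place of a group of 9 heavy atoms (9 carbon; one four-membered non-aromatic ring of carbon only, one six-membered aromatic ring of carbon only), on a saturated chain carbon, three bonds along the chain from an amine nitrogen in a ring. The entering group is 2,3-dihydro-1H-inden-1-yl. Among the measured compounds shown here, only one measured step bears on this change: a 7.9-fold higher number from compound 1 to compound 2 (0.90 log units; beyond the scatter). That step also alters the group at this place, but it keeps the four-membered non-aromatic ring, so it offers only indirect guidance on a five-membered one. With this single step as evidence, a shift towards a lower number is expected in this assay, somewhat smaller than the measured step and held with low confidence. The expected step is a 3.2-fold lower number from compound 2 to compound 3 (0.50 log units; beyond the scatter). The estimate for compound 3 is 0.45 mg/kg, with an expected range of 0.12 mg/kg to 1.6 mg/kg.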

Compound 3, dose for 50% inhibition: 0.29 mg/kg
Estimate against measurement, compound 3: 1.6-fold (0.19 log units) above; measured number inside the range.
By their numbers in this assay, from the lowest: compounds 1 and 3 (each within the scatter of the next); then compound 2.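

In this assay the ring size at this place counts on its own: with 2,3-dihydro-1H-inden-1-yl entering, the step is a 4.9-fold lower number from compound 2 to compound 3 (0.69 log units; beyond the scatter), although the leaving and entering groups match in heavy atoms. The same entering group, set against the smaller group of compound 1, gives a 1.6-fold higher number from compound 1 to compound 3 (0.21 log units; within the scatter), so a group larger by heavy atoms does not on its own go with a higher number, and among these compounds only compound 2 stands apart. No measurement shown here accounts for the gap between the four-membered and five-membered ring groups.

From the compounds shown here alone, it stays open whether a longer chain on the 2,3-dihydro-1H-inden-1-yl group would shift the number as the four-membered ring series does. A 1,2,3,4-tetrahydronaphthalen-1-yl group at this place also remains untested in the compounds shown.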